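Swapping the aryl group on the core of compound 1

A few compounds are considered here, and "the series" means these few. Any claim that something is new, unique, unknown or untested is made for them only; others in the source may bear on it.

Compound 1 `O=C(NO)c1ccc(Cn2nnc(-c3ccccn3)n2)cc1` is read in an assay on Sf9 cells for inhibition of protein deacetylase HDAC6 (Homo sapiens), read by fluorescence (a higher number here means a weaker inhibitor, a lower number a stronger inhibitor), where compound 1 gives 9 nM. Among the three numbers in hand, compound 1 holds the second highest. Compound 2 `O=C(NO)c1ccc(Sc2nnc(-c3ccccc3)o2)cc1` gives 6 nM in this assay, a number within the scatter of that of compound 1. Compound 3 `NCc1ccc(C(=O)NO)cc1` gives 695 nM in this assay, a number beyond the scatter from compound 1; compound 3 lacks the larger portion that compound 1 and compound 2 both carry on the benzohydroxamic acid.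

Compound 4 `NCc1ccc(-c2nnn(Cc3ccc(C(=O)NO)cc3)n2)cc1` has not been measured. It differs from compound 1 in one place: 4-(aminomethyl)phenyl in place of pyridin-2-yl on an aromatic carbon. For the measured compounds named here, no step between two measured compounds matches this exchange, so its size rests on judgement. Compound 1 and compound 2 show that two different large groups give close numbers, while compound 3, without such a group, sits far higher. Compound 4 keeps the large group and alters only its outer ring, so the step from compound 1 to compound 4 is expected to be a 1.7-fold higher number from compound 1 to compound 4 (0.22 log units; within the scatter), small and near the scatter. Compound 4 is expected to give 15 nM in this assay, with a range from 5 nM to 50 nM.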

Compound 4, half-maximal inhibitory concentration: 2 nM
Beside the measured number, compound 4's estimate is 7.5-fold (0.88 log units) above it; measured number below the stated range.
By their numbers in this assay, from the lowest: compound 4; then compounds 2 and 1 (each within the scatter of the next); then compound 3.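

For the compounds shown here, on the aromatic carbon of the five-membered aromatic ring with 4 nitrogen, the outer group does matter in this assay: 4-(aminomethyl)phenyl in place of pyridin-2-yl gives a 4.5-fold lower number from compound 1 to compound 4 (0.65 log units; beyond the scatter), the first measured change at this position and a modest one. The position therefore tolerates the larger group, with 8 heavy atoms entering for 6 and a hydrogen-bond donor gained, and the number still falls. Nothing in hand explains the step, which combines a change of ring with the added aminomethyl group.

Still open, on these data alone, is whether the amine carries the step: a plain phenyl or a hydroxymethyl group in its place on the outer ring would separate the two changes. Also open, as far as these compounds go, is how a carboxylic acid or a longer aminoalkyl chain would read at the same spot.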